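The compounds below may be only part of what the source reports. "The series", "measured", "known", "first", "only" and "open" are said of these compounds alone.

Three thiosemicarbazones have been examined in a toxicity assay on MRC5 cells (Homo sapiens) for cytotoxicity, read by MTT assay, with a stated time of 72 h; on this read-out higher numbers stand for an effect only at larger amounts of compound and lower numbers for an effect already at smaller amounts. Compound 1 `Cn1cc(/C=N/NC(N)=S)c2ccccc21` reaches only the limit of the assay, > 200000 nM, which is a limit rather than a number. Compound 2 `CCCCn1cc(/C=N/NC(N)=S)c2cccc(C)c21` gives 31000 nM in this assay. Compound 3 `COc1ccc(/C=N/NC(N)=S)c2ccccc12`, which carries a methoxy group on its core, gives 42000 nM in this assay; this is the higher of the two real numbers, and its gap to compound 2 lies within the scatter of repeated measurements, so the two cannot be told apart. The limit reached by compound 1 is described by the limit of > 200000 nM in this assay, at which 1 of the 3 values shown sits.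

Compound 4 `NC(=S)N/N=C/c1ccc(OCC2CCCCC2)c2ccccc12` has not yet been measured in this assay. It differs from compound 3 by one change: cyclohexyl in place of hydrogen on a saturated chain carbon bound to an oxygen on an aromatic ring. Going by the values given here, no pair of measured compounds differs in a single place, so no measured step is available to guide an expectation for this change. The expectation for the step from compound 3 to compound 4 is therefore only a guess: a modest move toward a lower number, estimated as a 2.1-fold lower number from compound 3 to compound 4 (0.32 log units; beyond the scatter), with the honest possibility that it stays within the scatter. Compound 4 is estimated at 20000 nM in this assay, within a range from 5000 nM to 80000 nM.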

Compound 4, half-maximal effective concentration: 28900 nM
Beside the measured number, compound 4's estimate is 1.4-fold (0.16 log units) below it; the range from low to high includes it.
By their numbers in this assay, from the lowest: compounds 4, 2 and 3 (each within the scatter of the next). At a limit, above all of these: compound 1.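

Going by these compounds alone, a single change can now be read in this assay for the first time: a 1.5-fold lower number from compound 3 to compound 4 (0.16 log units; within the scatter) is what going from methoxy to cyclohexylmethoxy gives. Because this step lies within the scatter, compound 3 and compound 4 cannot be told apart, so a cyclohexyl, one six-membered non-aromatic ring of carbon only, can replace a hydrogen on this saturated chain carbon bound to an oxygen on an aromatic ring without a difference that this read-out can resolve. Nothing measured here bears on why the step stays so small.

Within the data shown here, this is only one step at one place, so it remains open whether an amine, a carboxylic acid, a phenyl ring or a longer chain carried on the same oxygen would also stay within the scatter or would move the number clearly in either direction. From the compounds shown here alone, it also remains open how the cyclohexylmethoxy group relates to compound 1 and compound 2, since each of these differs from compound 4 in more than one place.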